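Oxadiazole aryl series: expectation for the nitrophenyl analogue

The source may report more compounds than this note shows. Statements on the series, on what has been measured and on what is new or still open speak of the compounds shown alone.

Measured compounds:
- Compound 1 `Cc1nnc(COc2cnn(C(C)(C)C)c(=O)c2Cl)o1` — in a functional assay on the whole organism for inhibition, with Mythimna separata as the target, with a stated time of 5 days (on this read-out higher numbers stand for an effect only at larger amounts of compound and lower numbers for an effect already at smaller amounts), compound 1 gives > 299000 nM, which is a limit of the assay and not a number.
- Compound 2 `CC(C)(C)n1ncc(OCc2nnc(-c3cccc(F)c3)o2)c(Cl)c1=O` — in this assay compound 2 gives 7100 nM.
- Compound 3 `CC(C)(C)n1ncc(OCc2nnc(-c3ccccc3)o2)c(Cl)c1=O` — in this assay compound 3 gives 12200 nM.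

Compound 3 holds the higher of the two numbers, with compound 2 nearest: a 1.7-fold higher number from compound 2 to compound 3 (0.24 log units; within the scatter). Compound 1 sits at a limit and ranks only as such.

Compound 4 `CC(C)(C)n1ncc(OCc2nnc(-c3ccc([N+](=O)[O-])cc3)o2)c(Cl)c1=O` differs from compound 3 by nitro in place of hydrogen on an aromatic carbon.

Three steps are known. an at least 42-fold lower number from compound 1 to compound 2 (1.62 log units; beyond the scatter) and an at least 24-fold lower number from compound 1 to compound 3 (1.38 log units; beyond the scatter) are both large, but each swaps the methyl for an aryl ring and so speaks to a different kind of change; the limit of > 299000 nM in this assay, at which 1 of the 3 values shown sits, also caps what they can say. Among the measured compounds shown here, the one step that alters a substituent on the aryl ring, a 1.7-fold higher number from compound 2 to compound 3 (0.24 log units; within the scatter), stays within the scatter. For the measured compounds named here, the nitro change has no direct precedent here, so the expectation for compound 4 in this assay is a step of no clear direction beyond the scatter, a 1.2-fold lower number from compound 3 to compound 4 (0.09 log units; within the scatter). Compound 4 is therefore estimated at 10000 nM, with a range from 3000 nM to 45000 nM.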

Compound 4, half-maximal effective concentration: > 299000 nM
Compound 4 ended at the assay's limit; the forecaster's own chance of this, stated with the estimate: 10%; middle value at least 29-fold (1.47 log units) from the limit.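

Among the compounds shown here, the para position on the phenyl ring of compound 3 is not indifferent to substitution: nitro in place of hydrogen brings an at least 24-fold higher number from compound 3 to compound 4 (1.38 log units; beyond the scatter) in this assay, the first large step that comes from a substituent on the aryl ring and not from replacing methyl with an aryl ring. Changing the ring substituent can therefore matter far more than the fluoro change suggested, since 4-nitrophenyl in place of 3-fluorophenyl brings an at least 42-fold higher number from compound 2 to compound 4 (1.62 log units; beyond the scatter), whereas the step without fluoro, a 1.7-fold higher number from compound 2 to compound 3 (0.24 log units; within the scatter), stays within the scatter. An aryl ring on its own also does not secure a readable value, as compound 4 carries one and still shares a limit of the assay with the methyl compound 1, so the step between these two cannot be read: the limit of > 299000 nM in this assay, at which 2 of the 4 values shown sit.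

Whether the loss belongs to nitro itself or to any substituent at this position stays open, as the compounds shown carry no other group there, such as fluoro, methoxy or an amine. Also open, from the compounds shown here alone, is how nitro would behave on the ring position that carries fluoro in compound 2.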